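Chlorophenyl exchange from compound 3 to compound 4

The source may hold more compounds than are shown below. What is called first, only, known or untested is meant among the compounds shown, and "the series" means these compounds.

In a functional assay on B16-F10 cells (Mus musculus) for inhibition, read by MTT assay, with a stated time of 72 h (a lower number here means a stronger inhibitor, a higher number a weaker inhibitor), compound 1 `CC1(C)CC(NC(=O)Nc2ccccc2)c2cc(Cl)ccc2O1` has the entry "not determined" (no result reported), so it offers no number for comparison. Compound 2 `CC1(C)CC(NC(=O)Nc2ccccc2Cl)c2cc(Cl)ccc2O1` gives 20000 nM, and compound 3 `CC1(C)CC(NC(=O)Nc2ccc(Cl)cc2)c2cc(Cl)ccc2O1` gives 32000 nM. For the measured compounds named here, these two values lie within the scatter of each other, so compound 3 stands level with the only other number.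

Compound 4 `CC1(C)CC(NC(=O)Nc2cccc(Cl)c2)c2cc(Cl)ccc2O1` carries 3-chlorophenyl in place of 4-chlorophenyl on an amide-type nitrogen, with the same atoms joined differently: 3-chlorophenyl in place of 4-chlorophenyl on an amide-type nitrogen.

Going by the values given here, one measured step bears on this change: a 1.6-fold higher number from compound 2 to compound 3 (0.20 log units; within the scatter). It is also an exchange of one chlorophenyl for another on that nitrogen, and it stays within the scatter. A single step of this size supports no trend with the chlorine position, so no change beyond the scatter is expected in this assay. The expected step, a 1.2-fold lower number from compound 3 to compound 4 (0.09 log units; within the scatter), has no firm direction. For compound 4 the estimated value is 26000 nM, with an expected range of 13000 nM to 50000 nM.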

Compound 4, half-maximal inhibitory concentration: 25000 nM
The estimate for compound 4 lay 1.0-fold (0.02 log units) above the measured number; measured number inside the range.
By their numbers in this assay, from the lowest: compounds 2, 4 and 3 (each within the scatter of the next).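

With 3-chlorophenyl in place of 4-chlorophenyl on an amide-type nitrogen, this assay gives a 1.3-fold lower number from compound 3 to compound 4 (0.11 log units; within the scatter) and, against the third chlorine placement, a 1.3-fold higher number from compound 2 to compound 4 (0.10 log units; within the scatter) as its second new step. Compound 2, compound 3 and compound 4 now cover 2-chlorophenyl, 4-chlorophenyl and 3-chlorophenyl, and every step among them lies within the scatter, so moving the chlorine around this phenyl shows no readable effect in this assay across these three compounds. No independent data bear on this result, so it remains a plain observation.

Still open, as far as these compounds go, is how a group other than chlorine on this phenyl, such as methoxy, an amine or a carboxylic acid, would read. Also open, from the compounds shown here alone, are whether the unsubstituted phenyl of compound 1 differs from the chlorophenyl compounds, and how changes to the shared core would read.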